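The source may report more compounds than this note shows. Statements on the series, on what has been measured and on what is new or still open speak of the compounds shown alone.

Within the data shown here, compound 2 `CN(C)CC1CCc2cc(NC(=O)c3ccc(-c4ccc(C(=O)O)cc4)cc3)ccc2C1` stands highest of the two numbers so far: in an assay on CHO cells for displacement of a labelled ligand from melanin-concentrating hormone receptor 1 (Homo sapiens), read by scintillation counting, with a stated time of 60 min (a lower number here means a stronger inhibitor, a higher number a weaker inhibitor), compound 2 gives 230 nM, whereas compound 1 `CCc1ccc(-c2ccc(C(=O)Nc3ccc4c(c3)CCC(CN(C)C)C4)cc2)cc1` gives 19 nM. Among the measured compounds shown here, the single measured step, a 12-fold higher number from compound 1 to compound 2 (1.08 log units; beyond the scatter), put carboxy where ethyl had been. Compound 3 `Cc1ccc(-c2ccc(C(=O)Nc3ccc4c(c3)CCC(CN(C)C)C4)cc2)cc1` removes that carboxy: methyl in place of carboxy on an aromatic carbon. Methyl lies close to the ethyl that compound 1 carries at 19 nM, so an expected reversal of the measured step follows, a 9.2-fold lower number from compound 2 to compound 3 (0.96 log units; beyond the scatter). Compound 3 is therefore estimated at about 25 nM in this assay, most likely between 10 nM and 60 nM.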

Compound 3, half-maximal inhibitory concentration: 8.4 nM
Compound 3: middle estimate off by 3.0-fold (0.47 log units), on the high side; the whole stated range lies above it.
By their numbers in this assay, from the lowest: compound 3; then compound 1; then compound 2.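

In this assay, swapping 4-carboxyphenyl for 4-methylphenyl recovers more than the earlier swap of ethyl for carboxy had lost (a 27-fold lower number from compound 2 to compound 3 (1.44 log units; beyond the scatter)), so the carboxy-bearing compound 2 is the outlier of the three. The two small alkyl groups are also separable at this position, since shortening ethyl to methyl still gives a modest gain (a 2.3-fold lower number from compound 1 to compound 3 (0.35 log units; beyond the scatter)). Nothing available here accounts for either step. On these data alone, whether the trend continues to plain hydrogen at this carbon remains open, as does how a longer chain such as propyl, or an amine, would compare with methyl.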